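This account rests on a few compounds, and the source may have more. Where it says the series, first, only, none or still open, it means among the compounds named here.

Compound 1 `O=C(Nc1cccc(/C=C/C(=O)c2nc3ccccc3[nH]2)c1)c1ccccc1` carries a benzoyl group on its amide nitrogen and sits at the higher end of what has been measured: in a functional assay on 143B cells (Homo sapiens) for antiproliferative activity, read by MTT assay, with a stated time of 48 h (on this read-out lower numbers stand for stronger inhibition and higher numbers for weaker inhibition), compound 1 gives 8340 nM, the highest of the two numbers available. For the measured compounds named here, its only measured neighbour is compound 2 `O=C(/C=C/c1cccc(NC(=O)c2ccccc2Cl)c1)c1nc2ccccc2[nH]1`, which in this assay gives 3690 nM; the step of a 2.3-fold lower number from compound 1 to compound 2 (0.35 log units; beyond the scatter) is a modest gain that lies beyond the scatter.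

Compound 3 `O=C(Nc1cccc(/C=C/C(=O)c2nc3ccccc3[nH]2)c1)c1cccc(Cl)c1` differs from compound 1 by chloro in place of hydrogen on an aromatic carbon. Going by the values given here, the one measured step that bears on this is the exchange of chloro for hydrogen on an aromatic carbon, a 2.3-fold lower number from compound 1 to compound 2 (0.35 log units; beyond the scatter), the same kind of substitution though not the same one. On that basis a modest lowering of the number is expected for compound 3 as well, of about the size seen there, rather than no change beyond the scatter or a rise.

Compound 3 is therefore estimated to give 4200 nM in this assay, within a range of 2000 nM to 9000 nM, which would be a step of a 2.0-fold lower number from compound 1 to compound 3 (0.30 log units; within the scatter).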

Compound 3, half-maximal inhibitory concentration: 3370 nM
Estimate against measurement, compound 3: 1.2-fold (0.10 log units) above, and the stated range covers the measured number.
By their numbers in this assay, from the lowest: compounds 3 and 2 (each within the scatter of the next); then compound 1.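

The exchange of phenyl for 3-chlorophenyl in this assay gives a 2.5-fold lower number from compound 1 to compound 3 (0.39 log units; beyond the scatter), so the lowering seen with compound 2 is not tied to a single placement of chloro: both chlorinated compounds stand beyond the scatter of compound 1. Between the two chlorinated compounds, 3-chlorophenyl in place of 2-chlorophenyl gives a 1.1-fold lower number from compound 2 to compound 3 (0.04 log units; within the scatter), which means that this read-out does not separate the two placements and that, across these compounds, the presence of chloro on the phenyl group matters more than which of the two places it occupies. Nothing available accounts for the lowering or for the match between the two placements.

On these data alone, it remains open whether the effect belongs to chloro itself or would also appear with fluoro, methoxy, trifluoromethyl or an amine in the same place on the phenyl group. The compounds shown also leave open whether a second chloro on the same phenyl group would lower the number further or add nothing beyond the scatter.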